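Swapping chloro for fluoro: a solubility outlook for compound 4

The compounds below may be only part of what the source reports. "The series", "measured", "known", "first", "only" and "open" are said of these compounds alone.

Compound 1 `CCCS(=O)(=O)Nc1ccc(Cl)c(C(=O)Nc2cnc3[nH]nc(OC)c3c2)c1F`: in a physicochemical assay for solubility, at pH 6.5 (on this read-out higher numbers stand for higher solubility and lower numbers for lower solubility), compound 1 gives < 1 ug/mL, which is a limit of the assay.
Compound 2 `CCCS(=O)(=O)Nc1ccc(F)c(C(=O)Nc2cnc3[nH]nc(C4CC4)c3c2)c1F`: in this assay compound 2 gives 1 ug/mL.
Compound 3 `CCCS(=O)(=O)Nc1ccc(F)c(C(=O)Nc2cnc3[nH]nc(OC)c3c2)c1Cl`: in this assay compound 3 gives < 1 ug/mL, which is a limit of the assay.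

Compound 3 thus stands not at a number but at the limit of < 1 ug/mL in this assay, at which 2 of the 3 values shown sit. Compound 4 `CCCS(=O)(=O)Nc1ccc(F)c(C(=O)Nc2cnc3[nH]nc(OC)c3c2)c1F` differs from it by fluoro in place of chloro on an aromatic carbon. For the measured compounds named here, no pair of measured compounds differing in a single place exists here, so the size of such a change has not been observed. Compound 2, which also carries two fluoro groups, sits at 1 ug/mL in this assay. The expected step is a number no lower from compound 3 to compound 4 (the limit leaves the size open), nothing beyond the usual scatter. Compound 4 is therefore estimated at 1 ug/mL, between 0.3 ug/mL and 3 ug/mL, and may well again be reported only as a limit.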

Compound 4, solubility: 4 ug/mL
Compound 4: the middle estimate sits 4.0-fold (0.60 log units) below what was measured, outside the stated range (above it).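

Fluoro in place of chloro on an aromatic carbon ortho to a (propylsulfonyl)amino group gives an at least 4.0-fold higher number from compound 3 to compound 4 (0.60 log units; beyond the scatter) in this assay, and the same swap at a different aromatic carbon gives an at least 4.0-fold higher number from compound 1 to compound 4 (0.60 log units; beyond the scatter), so the read-out responds to this change at both places. Methoxy in place of cyclopropyl gives a 4.0-fold higher number from compound 2 to compound 4 (0.60 log units; beyond the scatter), so with both fluoro groups present, that group counts as well. The two chloro steps start from a limit, so their full size stays open: the limit of < 1 ug/mL in this assay, at which 2 of the 4 values shown sit.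

Still open, going by these compounds, is how the number would move with an amine or a carboxylic acid in place of the propyl chain.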